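The compounds below may be only part of what the source reports. "The series", "measured", "known", "first", "only" and "open" are said of these compounds alone.

Measured in a functional assay on HT-29 cells (Homo sapiens) for antiproliferative activity, read by MTT assay, with a stated time of 72 h; a lower number here means a stronger inhibitor, a higher number a weaker inhibitor:
Compound 1 `COc1ccc(-n2ccnc2-c2cc(OC)c(OC)c(OC)c2)cc1[N+](=O)[O-]`: 600 nM
Compound 2 `COc1cc(-c2nccn2-c2cccc([N+](=O)[O-])c2)cc(OC)c1OC`: > 100000 nM (a limit of the assay)

Going by the values given here, compound 1 holds the only true number, since the entry for compound 2 is a limit. Among the compounds with values here, the single measured step, an at least 160-fold higher number from compound 1 to compound 2 (2.22 log units; beyond the scatter), is large and replaces methoxy with hydrogen. Compound 3 `COc1ccc(-n2ccnc2-c2cc(OC)c(OC)c(OC)c2)cc1O` keeps that methoxy group and has hydroxy in place of nitro on an aromatic carbon. This swap differs from the measured one, so that step shows only that a single substitution can matter greatly. A moderate move to a lower number in this assay is expected, though with wide uncertainty. The expected change is a 3.0-fold lower number from compound 1 to compound 3 (0.48 log units; beyond the scatter). For compound 3 the estimate is 200 nM, with an expected range of 20 nM to 2000 nM.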

Compound 3, half-maximal inhibitory concentration: 16900 nM
Beside the measured number, compound 3's estimate is 85-fold (1.93 log units) below it; the measured number lies above the stated range.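

In this assay, hydroxy in place of nitro, ortho to a methoxy group, gives a 28-fold higher number from compound 1 to compound 3 (1.45 log units; beyond the scatter), so the nitro-bearing carbon is a sensitive place too, which the earlier step at the methoxy group could not show. Unlike the earlier step, this one ends in a true number rather than a limit, so its size can be read exactly. Nothing given here accounts for the size of this step. The compounds shown leave open how an amine or a nitrile would read at this place, and so whether losing nitro or gaining hydroxy sets the change.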